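This account rests on a few compounds, and the source may have more. Where it says the series, first, only, none or still open, it means among the compounds named here.

The measured compounds and their values:

Compound 1, `C[C@@H](NC(=O)Nc1ccccc1F)c1ccccc1`, gives 97%.
Compound 2, `C[C@@H](NC(=O)Nc1cccc(F)c1)c1ccccc1`, gives 99%.
Compound 3, `C[C@@H](NC(=O)Nc1ccccc1Cl)c1ccccc1`, gives 101%.

All three were run in an ADME assay on the whole organism with Oryza sativa as the target, tested at 0.1 uM; on this read-out higher numbers stand for a weaker effect at the one concentration tested and lower numbers for a stronger effect. The difference between the core of compound 1 and the core of compound 2 is not broken down here. Compound 1 and compound 3 differ in one place, (chloro in place of fluoro on an aromatic carbon), and the step was a number 4 percentage points higher from compound 1 to compound 3 (within the scatter). Compound 2 sits between its two neighbours, and all three values lie within the scatter of one another.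

Compound 4, `C[C@@H](NC(=O)Nc1cccc(Cl)c1)c1ccccc1`, has not yet been measured in this assay. It differs from compound 2 by chloro in place of fluoro on an aromatic carbon. This is the same kind of change as that from compound 1 to compound 3, but the place is not the same: there the entering group stands ortho to a large group, here meta to a large group. Because the step of a number 4 percentage points higher from compound 1 to compound 3 (within the scatter) stayed within the scatter, the step from compound 2 to compound 4 is expected to be about a number 2 percentage points higher from compound 2 to compound 4 (within the scatter). Compound 4 is therefore estimated at 101%, with a range from 93% to 109%.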

Compound 4, a percentage reported as activity, at one concentration (the size of the read-out at that concentration, not a potency): 97%
Compound 4: middle estimate off by 4 percentage points, on the high side; the measured number falls inside the stated range.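

In this assay, chloro in place of fluoro on an aromatic carbon, meta to a large group, gave a number 2 percentage points lower from compound 2 to compound 4 (within the scatter). Set beside the same change on the other core, this new step shows no difference that can be told from the scatter: the same change on two cores in this assay, a number 4 percentage points higher (within the scatter) from compound 1 to compound 3 and a number 2 percentage points lower (within the scatter) from compound 2 to compound 4, 6 percentage points apart, within the scatter of two such steps

This shows that, on both cores, the exchange of fluoro for chloro left the read-out within the scatter, but it does not show that the change has the same size or sign on the two cores, and the chloro does not stand in the same place on them.

The compounds shown leave open whether a group other than a single fluoro or chloro on that aromatic ring, such as a methoxy group, a nitrile or a carboxylic acid, would move the number beyond the scatter. They also leave open how any of these compounds would behave at another concentration, as the read-out comes from one concentration only.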